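Bromo for Chloro at the Upper Edge of Growth Inhibition

The compounds below may be only part of what the source reports. "The series", "measured", "known", "first", "only" and "open" are said of these compounds alone.

Compound 1, `CC(C)(C)NCc1c(C(=O)O)nn(-c2ccccc2)c1-c1ccc(Cl)cc1`, gives 145000 nM in a functional assay on PC-3 cells (Homo sapiens) for inhibition, read by sulforhodamine B assay, with a stated time of 48 h; a higher number here means a weaker inhibitor of growth, a lower number a stronger inhibitor of growth.
Compound 2, `CC(C)(C)NCc1c(C(=O)O)nn(-c2ccccc2)c1-c1ccc(Br)cc1`, reaches only a limit of this assay, > 585000 nM.
Compound 3, `CC(C)(C)NCc1c(C(=O)O)nn(-c2ccc(Cl)cc2)c1-c1ccc(Cl)cc1`, likewise reaches only a limit of this assay, > 599000 nM.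

Compound 4, `CC(C)(C)NCc1c(C(=O)O)nn(-c2ccc(Cl)cc2)c1-c1ccc(Br)cc1`, has not yet been measured. It stands to compound 3 as compound 2 stands to compound 1: the change is the same, (bromo in place of chloro on an aromatic carbon), and the place around it reads the same word for word as in bromo in place of chloro on an aromatic carbon. In the measured pair that change gave an at least 4.0-fold higher number from compound 1 to compound 2 (0.60 log units; beyond the scatter), an open-ended figure because the limit of > 585000 nM in this assay, at which 1 of the 3 values shown sits, caps what can be read for compound 2. The two cores differ by chloro in place of hydrogen on an aromatic carbon, and that step gave an at least 4.1-fold higher number from compound 1 to compound 3 (0.61 log units; beyond the scatter), again open-ended because the limit of > 599000 nM in this assay, at which 1 of the 3 values shown sits, caps what can be read for compound 3. Compound 3 therefore already sits where the assay stops counting. The step from compound 3 to compound 4 is expected to be a step that the limit leaves unreadable from compound 3 to compound 4, since the earlier bromo change weakened inhibition rather than strengthened it. Compound 4 is estimated at 1500000 nM, most likely reported only as a limit, with a plausible range of 500000 nM to 5000000 nM.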

Compound 4, concentration for 50% growth inhibition: > 542000 nM
Compound 4: no number, only a limit; the forecaster's own chance of this, stated with the estimate: 85%; the middle value does not contradict the limit.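

In this assay compound 4 reaches only a limit, > 542000 nM. Compound 2 and compound 3 also stand at limits, and neither step to compound 4 can be read. The compounds shown leave open what bromo in place of chloro does on the core of compound 3, and where compound 2, compound 3 and compound 4 would truly fall.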